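The compounds below may be only part of what the source reports. "The series", "measured", "known", "first", "only" and "open" are said of these compounds alone.

Compound 3 `COc1cc(-c2nn(-c3cccc(NC(=O)c4ccc(Cl)c(C(F)(F)F)c4)c3)cc2-c2ccncc2)ccc1Cl` sits at the edge of what a functional assay on OVCAR-5 cells (Homo sapiens) for inhibition, read by sulforhodamine B assay, with a stated time of 48 h (a lower number here means a stronger inhibitor of growth, a higher number a weaker inhibitor of growth), can report: its value > 32500 nM is a limit rather than a number, and (the limit of > 32500 nM in this assay, at which 1 of the 3 values shown sits). Its two measured relatives give numbers. Compound 1 `COc1cc(-c2nn(-c3cccc(NC(=O)c4cccc(C(F)(F)F)c4)c3)cc2-c2ccncc2)ccc1Cl` gives 4010 nM in this assay, and compound 2 `COc1cc(-c2nn(-c3cccc(NC(=O)Nc4cccc(C(F)(F)F)c4)c3)cc2-c2ccncc2)ccc1Cl` gives 1270 nM. Compound 4 `COc1cc(-c2nn(-c3cccc(NC(=O)c4ccccc4)c3)cc2-c2ccncc2)ccc1Cl` differs from compound 3 by phenyl in place of 4-chloro-3-(trifluoromethyl)phenyl on a carbonyl carbon. The step that bears most directly is an at least 8.1-fold higher number from compound 1 to compound 3 (0.90 log units; beyond the scatter), which compound 4 undoes by removing that chloro; it also drops the trifluoromethyl, a change not tested here. The step of an at least 25-fold higher number from compound 2 to compound 3 (1.40 log units; beyond the scatter) points the same way. A lower number is therefore expected for compound 4, roughly of the size seen from compound 1 to compound 3. Compound 4 is estimated at 4000 nM, between 900 nM and 18000 nM, meaning an at least 8.1-fold lower number from compound 3 to compound 4 (0.90 log units; beyond the scatter).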

Compound 4, concentration for 50% growth inhibition: 15000 nM
For compound 4 the middle estimate is 3.8-fold (0.57 log units) below the measured one, and the stated range covers the measured number.
By their numbers in this assay, from the lowest: compound 2; then compound 1; then compound 4. At a limit, above all of these: compound 3.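

In this assay, the trifluoromethyl now has a measured effect of its own: hydrogen in its place gives a 3.7-fold higher number from compound 1 to compound 4 (0.57 log units; beyond the scatter), and replacing the whole (3-(trifluoromethyl)phenyl)amino group with phenyl gives a 12-fold higher number from compound 2 to compound 4 (1.07 log units; beyond the scatter). Yet plain phenyl still outperforms 4-chloro-3-(trifluoromethyl)phenyl, with an at least 2.1-fold lower number from compound 3 to compound 4 (0.33 log units; beyond the scatter), so among these compounds the trifluoromethyl goes with a lower number only when the chloro is absent. Compound 3 remains a limit rather than a number: the limit of > 32500 nM in this assay, at which 1 of the 4 values shown sits.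

From the compounds shown here alone, what a chloro does on the phenyl without the trifluoromethyl stays open. So does the effect of a methoxy or an amine on that same aromatic carbon.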